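A Methyl Added Where Only Limits Are Known

A few compounds are considered here, and "the series" means these few. Any claim that something is new, unique, unknown or untested is made for them only; others in the source may bear on it.

Compound 1 (`COc1nn(C)c2ncnc(NS(=O)(=O)c3cccc(Cl)c3Cl)c12`) is the starting point. In a physicochemical assay for solubility, read by chemiluminescence, measured as kinetic solubility (on this read-out higher numbers stand for higher solubility and lower numbers for lower solubility), compound 1 gives >= 581000 nM as a limit of the assay and not as a number. Compound 2 (`COCCOc1nn(C)c2ncnc(NS(=O)(=O)c3cccc(Cl)c3Cl)c12`) gives >= 463000 nM as a limit too. Compound 3 (`COc1nn(CC(=O)O)c2ncnc(NS(=O)(=O)c3cccc(Cl)c3Cl)c12`) gives >= 483000 nM as a limit as well. All three measured compounds therefore stand at limits, and none offers a plain number for comparison.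

Compound 4 (`COc1nn(C)c2nc(C)nc(NS(=O)(=O)c3cccc(Cl)c3Cl)c12`) keeps the core of compound 1 and differs in one place (methyl in place of hydrogen on an aromatic carbon): methyl in place of hydrogen on an aromatic carbon, between two ring nitrogen atoms.

Within the data shown here, two measured steps bear on this change, though only loosely: a step that the two limits leave unreadable from compound 1 to compound 2 and a step that the two limits leave unreadable from compound 1 to compound 3 have no size that can be read. Both of those changes sit on a saturated chain carbon, whereas the new methyl sits on an aromatic carbon. The expectation therefore rests on compound 1 with its limit of >= 581000 nM and predicts no step beyond the usual scatter in this assay in either direction. On this estimate the expected move is an at least 1.2-fold lower number from compound 1 to compound 4 (0.08 log units; that floor lies within the scatter) and no more. Compound 4 is expected at 480000 nM with an estimated range from 180000 nM to 620000 nM and may return only a limit.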

Compound 4, solubility: >= 557000 nM
Compound 4: a limit, no number; the forecaster's own chance of this, stated with the estimate: 70%; at least 1.1-fold (0.06 log units) between middle value and limit.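

Compound 4, like compound 1, stands at a limit of the assay and not at a number, so the step between these two compounds cannot be read. The compounds shown leave open what the actual solubility of each one is, and whether methyl in place of hydrogen on this aromatic carbon changes it at all.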